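This account rests on a few compounds, and the source may have more. Where it says the series, first, only, none or still open, it means among the compounds named here.

For the measured compounds named here, in a functional assay on HCT-116 cells (Homo sapiens) for antiproliferative activity, read by MTT assay, with a stated time of 72 h (a higher number here means a weaker inhibitor, a lower number a stronger inhibitor), compound 1 `NC1=NC2(CCSCC2)N(OCCCOc2cccc(Cl)c2)C(N)=N1` gives 1 nM, the lowest number of the three measured so far. Compound 2 `NC1=NC2(CCOCC2)N(OCCCOc2ccccc2Cl)C(N)=N1` gives 70 nM, and compound 3 `NC1=NC2(CCOCC2)N(OCCCOc2ccc(Cl)c(Cl)c2)C(N)=N1` gives 90 nM. Compound 4 `NC1=NC2(CCSCC2)N(OCCCOc2ccccc2Br)C(N)=N1` keeps the core of compound 1 and carries 2-bromophenyl in place of 3-chlorophenyl on an oxygen on a saturated carbon. Going by the values given here, the only measured step between two such groups, a 1.3-fold higher number from compound 2 to compound 3 (0.11 log units; within the scatter), lies within the scatter, but it sits on a different core, and no bromophenyl compound has been measured. Only a modest rise is therefore expected, an estimated 3.0-fold higher number from compound 1 to compound 4 (0.48 log units; beyond the scatter). For compound 4 the estimate is 3 nM, with an expected range of 0.7 nM to 15 nM.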

Compound 4, half-maximal inhibitory concentration: 1 nM
For compound 4 the middle estimate is 3.0-fold (0.48 log units) above the measured one; the measured number falls inside the stated range.
By their numbers in this assay, from the lowest: compounds 1 and 4 (each within the scatter of the next); then compounds 2 and 3 (each within the scatter of the next).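

On the core of compound 1, 2-bromophenyl in place of 3-chlorophenyl on an oxygen on a saturated carbon gives no change at the digits printed from compound 1 to compound 4 (within the scatter) in this assay. For the compounds shown here, this position therefore accepts a different halogen at a different ring position with no loss of the low number, something the earlier compounds, on another core, could not show. No available evidence explains this result.

Halogen and ring position changed together here, so their separate contributions remain unknown. Also open, from the compounds shown here alone, is whether this position would accept a carboxylic acid or an amine on the phenyl ring in place of the halogen.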